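The source may report more compounds than this note shows. Statements on the series, on what has been measured and on what is new or still open speak of the compounds shown alone.

Measured in an ADME assay on CCRF-HSB-2 cells (Homo sapiens) for cytotoxicity, with a stated time of 7 days; a lower number here means that less compound is tolerated, a higher number that more compound is tolerated:
- compound 1 `CCOc1nc(N)nc2c1ncn2/C=C1/CC1(CO)CO`: > 20000 nM (a limit)
- compound 2 `CN(C)c1nc(N)nc2c1ncn2/C=C1/CC1(CO)CO`: > 20000 nM (a limit)
- compound 3 `Nc1nc(NC2CC2)c2ncn(/C=C3/CC3(CO)CO)c2n1`: > 20000 nM (a limit)

Compound 3 stands at > 20000 nM, which is a limit and not a number. The same holds for the other two compounds, so the data show (the limit of > 20000 nM in this assay, at which 3 of the 3 values shown sit). Within the data shown here, no measured compound therefore gives a readable value from which to rank compound 3.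

The next compound, compound 4 `CSc1nc(N)nc2c1ncn2/C=C1/CC1(CO)CO`, carries methylsulfanyl in place of cyclopropylamino on an aromatic carbon. The change falls on the same aromatic carbon that varies among the measured compounds. Among the measured compounds shown here, three steps bear on it: a step that the two limits leave unreadable from compound 1 to compound 2, a step that the two limits leave unreadable from compound 1 to compound 3 and a step that the two limits leave unreadable from compound 2 to compound 3. None of them has a size that can be read, and none involves methylsulfanyl. All that they offer is that three different groups at this place left every result in this assay as a limit.

The expectation is therefore no readable step in either direction, and compound 4 will most likely be reported as a limit again. The step this estimate implies is expected to be a number no higher from compound 3 to compound 4 (the limit leaves the size open). For compound 4 the estimated value is 20000 nM, with an expected range from 8000 nM to 40000 nM.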

Compound 4, half-maximal cytotoxic concentration: > 100000 nM
Compound 4: only a limit was reported; the forecaster's own chance of this, stated with the estimate: 75%; middle value at least 5.0-fold (0.69 log units) away from the limit.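

In this assay compound 4 gives > 100000 nM, which is a limit and not a number. Compound 1, compound 2 and compound 3 also stand only as limits, so none of their steps to compound 4 can be read. The compounds shown leave open at what concentration any of them becomes cytotoxic, and how much the group on this aromatic carbon matters.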